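This account rests on a few compounds, and the source may have more. Where it says the series, first, only, none or still open, it means among the compounds named here.

Three compounds of the series have been run so far in a functional assay on the whole organism (strain albino) for inhibition, with Rattus norvegicus as the target, read by paw edema, with a stated time of 1 h, at a dose of 0.28 mmol/kg by the oral route; on this read-out higher numbers stand for more inhibition at the one dose given (going by the name of the read-out) and lower numbers for less inhibition:
compound 1, `C=CCn1c(SCC(=O)c2ccccc2)nnc1-c1ccccc1`, 43%
compound 2, `C=CCn1c(SC/C(=N\O)c2ccccc2)nnc1-c1ccc(OC)c(OC)c1`, 53%
compound 3, `CCn1c(SCC(=O)c2ccccc2)nnc1-c1ccc(OC)cc1`, 53%

Compound 2 stands level with compound 3 at the digits reported, and together the two hold the highest numbers of the three; compound 1 comes in with a number that differs from theirs only by a gap that lies within the usual scatter of repeated measurements of this kind, so no order among the three can be read from these figures. Going by the values given here, no pair of measured compounds differs in only one place, so no single measured step is available to guide the next one.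

Compound 4, `C=CCn1c(SCC(=O)c2ccccc2)nnc1-c1ccc(OC)c(OC)c1`, has not yet been run. It differs from compound 2 in one place: a group of 8 heavy atoms (7 carbon, 1 oxygen; one six-membered aromatic ring of carbon only) in place of a group of 9 heavy atoms (7 carbon, 1 nitrogen, 1 oxygen; one six-membered aromatic ring of carbon only), on a saturated chain carbon bound to a sulfur. The change is confined to a group on a saturated chain carbon bound to a sulfur, and compounds 1 and 3, which carry the entering benzoyl group there, give numbers not far from that of compound 2. On that basis no step beyond the scatter is expected in this assay, in either direction. The value of compound 4 in this assay is estimated at 48%, with a likely range of 35% to 60%. This estimate implies an expected step of a number 5 percentage points lower from compound 2 to compound 4 (within the scatter).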

Compound 4, a percentage reported as inhibition, in the whole organism at one dose (the size of the read-out at that dose, not a potency): 61%
Compound 4: the middle estimate sits 13 percentage points below what was measured; the measured number lies above the stated range.
By their numbers in this assay, from the lowest: compounds 1, 2, 3 and 4 (each within the scatter of the next, the first and the last beyond it).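

Going by these compounds alone, this is the first pair that differs in one place, and it gives a direct reading at the saturated chain carbon bound to a sulfur: in this assay, benzoyl in place of the group of 9 heavy atoms gives a number 8 percentage points higher from compound 2 to compound 4 (within the scatter). The exchange takes the count from 1 hydrogen-bond donor to 0 and from 2 hydrogen-bond acceptors to 1, and on this one pair the read-out stays within the scatter, so the position accepts either group at this dose and on the core of compound 2. Nothing available explains the result or ties it to any property of either group.

From the compounds shown here alone, what a clearly different group at this place would do remains open, for instance an amine, a carboxylic acid or a longer chain in place of benzoyl. Going by these compounds, it is also open whether the same exchange on another core gives a comparable step, and since this assay reports a single dose at a single time, the pair says nothing about potency.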